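The compounds below may be only part of what the source reports. "The series", "measured", "known", "first", "only" and "open" are said of these compounds alone.

Measured so far:
Compound 1, `C=C(c1cc(Cl)cc(Cl)c1OCc1ccccc1)C1COC2(CCCC2)OO1`: in a functional assay on HepG2 cells (Homo sapiens) for inhibition, read by MTT assay, with a stated time of 72 h (on this read-out higher numbers stand for weaker inhibition and lower numbers for stronger inhibition), compound 1 gives 13700 nM.
Compound 2, `C=C(c1ccc(Cl)c(Cl)c1)C1COC2(CCCC2)OO1`: in this assay compound 2 gives 62600 nM.

Of these two numbers, compound 2 stands highest, meaning the weaker inhibition of the pair; compound 1 sits at a lower number, and the gap between them is beyond the usual scatter. Compound 3, `C=C(c1ccc(Cl)c(Cl)c1Cl)C1COC2(CCCC2)OO1`, has not yet been measured. It differs from compound 2 in one place: chloro in place of hydrogen on an aromatic carbon. For the measured compounds named here, no measured pair shows this particular change on its own, so nothing in the data at hand tells how large its effect should be. With so little to go on, a small step in this assay is expected, leaning toward stronger inhibition, though an outcome staying within the scatter is just as plausible. Compound 3 is therefore expected to give about 40000 nM, within a range from 15000 nM to 100000 nM. This estimate means an expected step of a 1.6-fold lower number from compound 2 to compound 3 (0.19 log units; within the scatter).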

Compound 3, half-maximal inhibitory concentration: 8450 nM
For compound 3 the middle estimate is 4.7-fold (0.68 log units) above the measured one, and the stated range ends above it.
By their numbers in this assay, from the lowest: compounds 3 and 1 (each within the scatter of the next); then compound 2.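

In this assay, for the compounds shown here, chloro in place of hydrogen on an aromatic carbon, ortho to a chloro group and ortho to a large group, brings a 7.4-fold lower number from compound 2 to compound 3 (0.87 log units; beyond the scatter) and so gives the first clean reading of a single change in this small set. It shows that this ring position is not indifferent: one added heavy atom, with no charge and no hydrogen-bond donors or acceptors, moves the number clearly toward stronger inhibition. Nothing measured here explains how this chloro produces the shift.

The compounds shown leave open whether a fluoro, methyl or methoxy group at this same position would move the number as far. They also leave open whether this chloro would give a similar step in a compound with other groups on the ring.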